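Phenol analogue of the thiophene-free rhodanine dienyl series

The compounds below may be only part of what the source reports. "The series", "measured", "known", "first", "only" and "open" are said of these compounds alone.

Three compounds of the shared core have numbers in an assay on isolated protein for inhibition of protein tyrosine phosphatase type IVA 3 (Homo sapiens), tested at 5 ug/mL; on this read-out higher numbers stand for more inhibition at the one concentration tested (going by the name of the read-out) and lower numbers for less inhibition. Compound 1 `O=C1NC(=S)S/C1=C\C=C\c1ccccc1OCc1ccncc1` gives 39.4%. Compound 2 `O=C1NC(=S)S/C1=C\C=C\c1ccccc1Cl` gives 53.9%. Compound 3 `O=C1NC(=S)S/C1=C\C=C\c1ccccc1OCc1ccccc1Br` gives 63.1%, the highest of the three numbers; compound 2 lies within the scatter of it, while compound 1 lies beyond it.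

Compound 4 `O=C1NC(=S)S/C1=C\C=C\c1ccccc1O` is the untested member. The change from compound 3 is hydrogen in place of 2-bromobenzyl on an oxygen on an aromatic ring.

Within the data shown here, two measured steps bear on it, both modest and beyond the scatter: a number 23.7 percentage points higher from compound 1 to compound 3 (beyond the scatter) and a number 14.5 percentage points higher from compound 1 to compound 2 (beyond the scatter). Among the measured compounds shown here, both show that the group on the oxygen on the aromatic ring matters for this read-out, and that the two-ring arrangement of compound 3 gives the highest number so far. For the measured compounds named here, no measured step strips that position to a bare oxygen–hydrogen, so the direction is taken from the fact that compound 1 and compound 2, each with less at that place, sit lower. A drop beyond the scatter is expected, a number 21.1 percentage points lower from compound 3 to compound 4 (beyond the scatter). Compound 4 is estimated at 42%, range 25% to 58%.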

Compound 4, a percentage reported as inhibition, at one concentration (the size of the read-out at that concentration, not a potency): 51.9%
Beside the measured number, compound 4's estimate is 9.9 percentage points below it; the range from low to high includes it.
By their numbers in this assay, from the lowest: compound 1; then compounds 4, 2 and 3 (each within the scatter of the next, the first and the last beyond it).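

In this assay the bare hydroxy gives a baseline for the group on the oxygen: there is a number 11.2 percentage points lower from compound 3 to compound 4 (beyond the scatter) on losing 2-bromobenzyl and a number 12.5 percentage points higher from compound 1 to compound 4 (beyond the scatter) on losing (pyridin-4-yl)methyl, so the two groups sit on opposite sides of hydrogen. Hydroxy in place of chloro on the aromatic carbon gives a number 2 percentage points lower from compound 2 to compound 4 (within the scatter) and thus no separation between these two small groups, while only 2-bromobenzyl stands beyond the scatter of hydrogen in the upward direction. Nothing available explains these differences.

The compounds shown leave open whether the bromine or the benzyl ring carries the gain over hydrogen, which a plain benzyl on the oxygen would test. As far as these compounds go, a methyl on the oxygen, or an amine or carboxylic acid on that aromatic carbon, also remains open.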